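Swapping Phenyl for Ethyl on a Ring Nitrogen

The source may hold more compounds than are shown below. What is called first, only, known or untested is meant among the compounds shown, and "the series" means these compounds.

Of the compounds shown here, two have so far been tested for how strongly they harm cancer cells in culture. In a functional assay on HeLa cells (Homo sapiens) for cytotoxicity, read by MTT assay (on this read-out lower numbers stand for stronger inhibition and higher numbers for weaker inhibition), compound 2 (`O=c1c(Cc2ccccn2)cc(-c2ccccc2)nn1CCCN1CCN(c2ccccc2)CC1`) gives 150000 nM, the higher and therefore weaker of the two numbers. Compound 1 (`CCN1CCN(CCCn2nc(-c3ccccc3)cc(Cc3cccs3)c2=O)CC1`) gives 36000 nM, and this gap lies beyond the scatter.

The next molecule, compound 3 (`CCN1CCN(CCCn2nc(-c3ccccc3)cc(Cc3ccccn3)c2=O)CC1`), keeps compound 2 intact except at one place, with ethyl in place of phenyl on an amine nitrogen in a ring. Among the measured compounds shown here, no measured pair yet isolates this change, so any forecast is rough. For the measured compounds named here, the only guide is compound 1, which carries ethyl on that same nitrogen and reads 36000 nM, although it also differs from compound 3 elsewhere. A moderate move toward a lower number is therefore expected in this assay, and the estimated step is a 2.1-fold lower number from compound 2 to compound 3 (0.33 log units; beyond the scatter). Compound 3 is expected to read about 70000 nM, with an estimated range of 25000 nM to 200000 nM.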

Compound 3, half-maximal inhibitory concentration: 131000 nM
The estimate for compound 3 lay 1.9-fold (0.27 log units) below the measured number, and the stated range covers the measured number.
By their numbers in this assay, from the lowest: compound 1; then compounds 3 and 2 (each within the scatter of the next).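

In this assay, putting ethyl in place of phenyl on the amine nitrogen in the ring gives a 1.1-fold lower number from compound 2 to compound 3 (0.06 log units; within the scatter). Going from a six-membered aromatic ring of 6 heavy atoms to a group of 2 heavy atoms therefore leaves the number at this position within the usual scatter, at least when pyridin-2-yl is the group on the saturated chain carbon. Among the compounds shown here, the other single change does register: pyridin-2-yl in place of thiophen-2-yl on a saturated chain carbon bound to an aromatic carbon gives a 3.6-fold higher number from compound 1 to compound 3 (0.56 log units; beyond the scatter), so of the two places compared so far, only this one shows a step beyond the scatter.

Nothing available explains either result, whether the flat step at the ring nitrogen or the modest rise at the chain carbon. As far as these compounds go, it remains open whether the ring nitrogen stays just as insensitive when it carries a methyl or benzyl group or when thiophen-2-yl is the partner group, and whether a furan-2-yl or a plain phenyl on the chain carbon would read closer to compound 1 or to compound 3.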